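Swapping the anilino group of compound 1 for 2-methylphenyl

The source may hold more compounds than are shown below. What is called first, only, known or untested is meant among the compounds shown, and "the series" means these compounds.

Within the data shown here, compound 1 `COc1ccc(Nc2nc(-c3cccc(F)c3)nc3ccc(F)cc23)cc1` is the only member of this small set to return a number. In a functional assay on COLO 205 cells (Homo sapiens) for cytotoxicity, read by MTT assay, with a stated time of 48 h (on this read-out higher numbers stand for weaker inhibition and lower numbers for stronger inhibition), compound 1 gives 46800 nM. Compound 2 `Fc1cccc(-c2nc(Nc3ccccc3Br)c3cc(F)ccc3n2)c1` carries a 2-bromophenyl on the nitrogen on the aromatic ring. In this assay compound 2 returns > 50000 nM, which is a limit of the assay and not a number. Compound 3 `Nc1ccc(Nc2nc(-c3cccc(F)c3)nc3ccc(F)cc23)cc1` carries a 4-aminophenyl on that same nitrogen. In this assay compound 3 likewise returns > 50000 nM, a limit. Thus the limit of > 50000 nM in this assay, at which 2 of the 3 values shown sit, covers two of the three values shown, and compound 1 stands as the only measured point.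

Compound 4 `Cc1ccccc1Nc1nc(-c2cccc(F)c2)nc2ccc(F)cc12` differs from compound 1 by 2-methylphenyl in place of 4-methoxyphenyl on a nitrogen on an aromatic ring. Among the measured compounds shown here, the steps that bear on this change are those that also replace the group on the nitrogen on the aromatic ring or alter the methoxy: an at least 1.0-fold higher number from compound 1 to compound 2 (0.02 log units; that floor lies within the scatter) and an at least 1.0-fold higher number from compound 1 to compound 3 (0.02 log units; that floor lies within the scatter). Both end at the limit, and their floors lie within the scatter. The step that the two limits leave unreadable from compound 2 to compound 3 cannot be read, since both ends are limits. For the measured compounds named here, no step in this set is known to move beyond the scatter, so for compound 4 the expected step is a 1.1-fold higher number from compound 1 to compound 4 (0.03 log units; within the scatter), in effect none beyond the scatter, with a real chance that only a limit is reported. Compound 4 is therefore estimated at 50000 nM, in the range 25000 nM to 100000 nM.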

Compound 4, half-maximal inhibitory concentration: > 50000 nM
Compound 4: only a limit was reported; the forecaster's own chance of this, stated with the estimate: 60%; the middle value sits exactly at the limit.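

Replacing the 4-methoxyphenyl on the nitrogen with 2-methylphenyl gives an at least 1.0-fold higher number from compound 1 to compound 4 (0.02 log units; that floor lies within the scatter), so this change, which also removes the methoxy oxygen, adds a third group at this position that yields only a floor and no measured number. The steps from compound 2 to compound 4 and from compound 3 to compound 4 cannot be read, as both ends of each are limits, so 2-methylphenyl, 2-bromophenyl and 4-aminophenyl cannot be ordered at this position. Compound 1 thus remains the only measured point in this assay, while every other group shown on this nitrogen ends at the same limit: the limit of > 50000 nM in this assay, at which 3 of the 4 values shown sit.

In this assay compound 1 gives 46800 nM, so the compounds shown do not establish any step beyond the scatter, and it stays open what a cyclohexyl or a morpholine-bearing chain on that nitrogen would give. Also open, going by these compounds, is what the shared core would give with changes away from this nitrogen, such as an amine or a carboxylic acid in place of either fluoro group.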